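The source may report more compounds than this note shows. Statements on the series, on what has been measured and on what is new or still open speak of the compounds shown alone.

Compound 1 `Cc1ccc(Cn2c(/C=C3\SC(=S)N(CC(=O)O)C3=O)nc3ccccc32)cc1`: 1040 nM
Compound 2 `Cc1ccc(Cn2c(/C=C3\SC(=S)N(CC(=O)O)C3=O)nc3ccc(Cl)cc32)cc1`: 3960 nM
Compound 3 `O=C(O)CN1C(=O)/C(=C/c2nc3ccc(Cl)cc3n2Cc2ccccc2F)SC1=S`: 9570 nM

All three values come from a functional assay on MDA-MB-231 cells (Homo sapiens) for cytotoxicity, read by MTT assay, with a stated time of 48 h (on this read-out lower numbers stand for stronger inhibition and higher numbers for weaker inhibition), and compound 3 has the highest number of the three. Compound 4 `COc1ccc2nc(/C=C3\SC(=S)N(CC(=O)O)C3=O)n(Cc3ccccc3F)c2c1` differs from compound 3 by one swap, methoxy in place of chloro on an aromatic carbon.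

Within the data shown here, no measured step introduces methoxy. The nearest guide is chloro in place of hydrogen on an aromatic carbon, which gave a 3.8-fold higher number from compound 1 to compound 2 (0.58 log units; beyond the scatter). The other measured step, a 2.4-fold higher number from compound 2 to compound 3 (0.38 log units; beyond the scatter), concerns the 2-fluorophenyl group, which stays unchanged here.

Losing the chloro may reverse part of that first rise, so a modest drop is expected, though methoxy is not hydrogen. The expected change is a 1.6-fold lower number from compound 3 to compound 4 (0.20 log units; within the scatter). For compound 4 the estimated value is 6000 nM, within an expected range of 2500 nM to 14000 nM.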

Compound 4, half-maximal inhibitory concentration: 22400 nM
Beside the measured number, compound 4's estimate is 3.7-fold (0.57 log units) below it, outside the stated range (above it).
By their numbers in this assay, from the lowest: compound 1; then compound 2; then compound 3; then compound 4.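

In this assay methoxy in place of chloro brings a 2.3-fold higher number from compound 3 to compound 4 (0.37 log units; beyond the scatter) on this aromatic carbon, so taking the chloro away does not undo the rise seen when chloro replaced hydrogen. The position therefore separates these two groups, and with the 2-fluorophenyl group in place, chloro gives the lower number. No measurement shown here explains why methoxy gives the higher number.

As far as these compounds go, whether an amine or a nitrile on this carbon would give a lower number stays open. So does whether methoxy would have the same effect alongside the 4-methylphenyl group.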